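The source may hold more compounds than are shown below. What is called first, only, known or untested is meant among the compounds shown, and "the series" means these compounds.

Measured so far in a functional assay on HOP-62 cells (Homo sapiens) for inhibition, read by sulforhodamine B assay, with a stated time of 48 h; on this read-out higher numbers stand for weaker inhibition of growth and lower numbers for stronger inhibition of growth: compound 1 `COc1cc(-c2nn(-c3cccc(NC(=O)Nc4cccc(C(F)(F)F)c4)c3)cc2-c2ccncc2)ccc1Cl` gives 1340 nM; compound 2 `COc1cc(-c2nn(-c3cccc(NC(=O)c4ccc(Cl)c(C(F)(F)F)c4)c3)cc2-c2ccncc2)ccc1Cl` gives 13100 nM; compound 3 `COc1cc(-c2nn(-c3cccc(NC(=O)Nc4ccc(Cl)c(C(F)(F)F)c4)c3)cc2-c2ccncc2)ccc1Cl` gives 1310 nM.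

Compound 3 has the lowest number of the three, but a 1.0-fold lower number from compound 1 to compound 3 (0.01 log units; within the scatter) falls within the scatter, so no order between compound 1 and compound 3 is claimed; only a 10-fold lower number from compound 2 to compound 3 (1.00 log units; beyond the scatter) lies beyond it.

Compound 4 `COc1cc(-c2nn(-c3cccc(NC(=O)c4ccccc4)c3)cc2-c2ccncc2)ccc1Cl` differs from compound 3 by phenyl in place of (4-chloro-3-(trifluoromethyl)phenyl)amino on a carbonyl carbon. The same exchange of a urea for an aryl amide at the carbonyl carbon was seen as a 9.8-fold higher number from compound 1 to compound 2 (0.99 log units; beyond the scatter) and, in reverse, as a 10-fold lower number from compound 2 to compound 3 (1.00 log units; beyond the scatter). Going by the values given here, a step of comparable size toward weaker inhibition of growth is therefore expected, an 11-fold higher number from compound 3 to compound 4 (1.06 log units; beyond the scatter); the entering phenyl also lacks the substituents of the leaving group, for which no measured step exists, so the range is kept wide. Compound 4 is estimated at 15000 nM, between 5000 nM and 45000 nM.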

Compound 4, concentration for 50% growth inhibition: 8340 nM
Compound 4: middle estimate off by 1.8-fold (0.25 log units), on the high side; low and high end bracket the measured number.
By their numbers in this assay, from the lowest: compounds 3 and 1 (each within the scatter of the next); then compounds 4 and 2 (each within the scatter of the next).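

Both ureas stand apart from the unsubstituted phenyl on the carbonyl carbon, with a 6.4-fold higher number from compound 3 to compound 4 (0.80 log units; beyond the scatter) and a 6.2-fold higher number from compound 1 to compound 4 (0.79 log units; beyond the scatter) on closely similar exchanges. Among the two amides, a 1.6-fold lower number from compound 2 to compound 4 (0.20 log units; within the scatter) shows that the chloro and trifluoromethyl substituents on the phenyl make no readable difference. Across all four compounds the lower numbers go with the urea, and no compound goes against this. As far as these compounds go, whether a plain phenylamino or a methylamino group on the carbonyl carbon would hold the urea level remains open. No evidence at hand accounts for these steps.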